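Swapping 4-Chlorophenyl for 2-Fluorophenyl in Compound 3

The source may report more compounds than this note shows. Statements on the series, on what has been measured and on what is new or still open speak of the compounds shown alone.

In a functional assay on DU-145 cells (Homo sapiens) for inhibition, read by trypan blue exclusion, with a stated time of 96 h (on this read-out lower numbers stand for stronger inhibition of growth and higher numbers for weaker inhibition of growth), compound 1 `Cc1ccc(S(=O)(=O)/C(=C/c2ccc(O)c([N+](=O)[O-])c2)C(=O)c2ccc(Cl)cc2)cc1` gives 25000 nM, compound 2 `COc1ccccc1/C=C(\C(=O)c1ccc(Cl)cc1)S(=O)(=O)c1ccc(C)cc1` gives 1000 nM, and compound 3 `Cc1ccc(S(=O)(=O)/C(=C/c2ccc(Cl)cc2)C(=O)c2ccc(Cl)cc2)cc1` gives 1000 nM. Compound 3 therefore stands level with compound 2, and together they hold the lowest of the three numbers.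

Compound 4 `Cc1ccc(S(=O)(=O)/C(=C/c2ccccc2F)C(=O)c2ccc(Cl)cc2)cc1` keeps the rest of compound 3 and alters one group, on a double-bonded chain carbon bound to a double-bonded chain carbon: 2-fluorophenyl in place of 4-chlorophenyl on a double-bonded chain carbon bound to a double-bonded chain carbon.

All three measured steps concern this same place. Losing the 4-hydroxy-3-nitrophenyl group mattered greatly, with a 25-fold lower number from compound 1 to compound 2 (1.40 log units; beyond the scatter) and a 25-fold lower number from compound 1 to compound 3 (1.40 log units; beyond the scatter). Compound 4 does not carry that group, so the closer guide is the exchange of 2-methoxyphenyl for 4-chlorophenyl, which gave no change at the digits printed from compound 2 to compound 3 (within the scatter).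

No step beyond the scatter is therefore expected in this assay, and the expected change is no change at the digits printed from compound 3 to compound 4 (within the scatter). For the measured compounds named here, with only three measured compounds, this expectation is loose. Compound 4 is estimated at 1000 nM, with an expected range of 300 nM to 4000 nM.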

Compound 4, concentration for 50% growth inhibition: 2500 nM
Compound 4: the middle estimate sits 2.5-fold (0.40 log units) below what was measured; the measured number falls inside the stated range.
By their numbers in this assay, from the lowest: compounds 2 and 3 (each within the scatter of the next); then compound 4; then compound 1.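

In this assay, this position now separates groups that had looked alike: 2-fluorophenyl in place of 4-chlorophenyl gives a 2.5-fold higher number from compound 3 to compound 4 (0.40 log units; beyond the scatter), whereas the exchange of 2-methoxyphenyl for 4-chlorophenyl gave no step beyond the scatter. Fluoro in place of methoxy on an aromatic carbon likewise gives a 2.5-fold higher number from compound 2 to compound 4 (0.40 log units; beyond the scatter), yet this is small beside a 10-fold lower number from compound 1 to compound 4 (1.00 log units; beyond the scatter), so compound 4 still lies far closer to compound 2 and compound 3 than to the 4-hydroxy-3-nitrophenyl compound. Nothing available here explains why the 2-fluorophenyl group gives a higher number.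

The exchange in compound 4 alters both the halogen and its printed ring position, and the compounds shown do not tell these two changes apart. A 2-chlorophenyl or 4-fluorophenyl group at this place would bear on that question, while a 4-aminophenyl group remains an open case.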